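The source may report more compounds than this note shows. Statements on the series, on what has been measured and on what is new or still open speak of the compounds shown alone.

Compound 2 `CCNCC(=O)N1N=C(c2cc3ccccc3oc2=O)CC1c1ccccc1` was tested in a functional assay on HepG2 cells (Homo sapiens) for cytotoxicity, read by MTT assay, with a stated time of 48 h (on this read-out lower numbers stand for stronger inhibition and higher numbers for weaker inhibition), where compound 2 gives 30600 nM. Compound 1 `COc1ccccc1C1CC(C)=NN1C(=O)C[N+]1(C)CCCC1` gives 32200 nM in this assay, and the two numbers lie within the usual scatter of each other, so neither compound can be called the more active. Compound 3 `CN1CCN(CC(=O)N2N=C(c3cc4ccccc4oc3=O)CC2c2ccccc2)CC1` differs from compound 2 in one place: 4-methylpiperazin-1-yl in place of ethylamino on a saturated chain carbon bound to a carbonyl carbon. Within the data shown here, no measured pair shows what such a change does here, so the expected step is a 1.0-fold lower number from compound 2 to compound 3 (0.01 log units; within the scatter), nothing beyond the scatter in either direction. Compound 3 is estimated at 30000 nM, with a range from 12000 nM to 80000 nM.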

Compound 3, half-maximal inhibitory concentration: 33100 nM
Estimate against measurement, compound 3: 1.1-fold (0.04 log units) below; measured number inside the range.
By their numbers in this assay, from the lowest: compounds 2, 1 and 3 (each within the scatter of the next).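

Putting 4-methylpiperazin-1-yl in place of ethylamino gives a 1.1-fold higher number from compound 2 to compound 3 (0.03 log units; within the scatter) in this assay on this saturated chain carbon bound to a carbonyl carbon. The earlier compounds shown here could not show that a group with a six-membered ring and no hydrogen-bond donor can stand here without a step beyond the scatter. No available evidence explains this result.

From the compounds shown here alone, what a morpholine or a carboxylic acid would do at this position stays open, as does whether any group here can move the number beyond the scatter.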